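Chloromethylbenzyl purines: the chloro-to-amino step on the core

A few compounds are considered here, and "the series" means these few. Any claim that something is new, unique, unknown or untested is made for them only; others in the source may bear on it.

Measured compounds in a functional assay on MDA-MB-231 cells (Homo sapiens) for cytotoxicity, read by sulforhodamine B assay, with a stated time of 48 h; a lower number here means a stronger inhibitor of growth, a higher number a weaker inhibitor of growth:
compound 1 `ClCc1ccccc1Cn1cnc2c(Cl)nc(Cl)nc21`: 1380 nM
compound 2 `ClCc1cccc(Cn2cnc3c(Cl)nc(Cl)nc32)c1`: 3710 nM
compound 3 `Nc1nc(Cl)c2ncn(Cc3ccccc3CCl)c2n1`: 9550 nM

Compound 1 and compound 2 share the same atoms joined differently; the difference between the two cores is not broken down here. Compound 3 arises from compound 1 by one change, (amino in place of chloro on an aromatic carbon), and this gave a 6.9-fold higher number from compound 1 to compound 3 (0.84 log units; beyond the scatter) in this assay. Compound 4 `Nc1nc(Cl)c2ncn(Cc3cccc(CCl)c3)c2n1` is not yet measured; it arises from compound 2 by amino in place of chloro on an aromatic carbon, the same change made at the same place. Among the measured compounds shown here, because compound 1 to compound 3 showed a 6.9-fold higher number from compound 1 to compound 3 (0.84 log units; beyond the scatter), a step of comparable size is expected from compound 2 to compound 4, about a 5.9-fold higher number from compound 2 to compound 4 (0.77 log units; beyond the scatter), with the single precedent as the only basis. Compound 4 is thus estimated at 22000 nM in this assay, with a range from 8000 nM to 60000 nM.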

Compound 4, concentration for total growth inhibition: 28800 nM
Compound 4: middle estimate off by 1.3-fold (0.12 log units), on the low side, and the stated range covers the measured number.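

In this assay, amino in place of chloro on the aromatic carbon between two ring nitrogen atoms again weakens growth inhibition, a 7.8-fold higher number from compound 2 to compound 4 (0.89 log units; beyond the scatter). The step carries across the two cores at matching size: the same change on two cores in this assay, a 6.9-fold higher number (0.84 log units; beyond the scatter) from compound 1 to compound 3 and a 7.8-fold higher number (0.89 log units; beyond the scatter) from compound 2 to compound 4, 1.1-fold (0.05 log units) apart, within the scatter of two such steps. This rests on two matched pairs in one cell line, so it shows transfer only between these two closely related cores and gives no reason for the loss, nor any sign that it holds on other cores or in other cells.

Open, going by these compounds, is whether a methylamino or methoxy group at the same carbon would give a step of similar size. Also open, on these data alone, is how a hydroxymethyl or methyl group in place of the chloromethyl group would alter these numbers.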